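Thiophen-2-yl to thiophen-3-yl in the phenylsulfanyl series

The source may report more compounds than this note shows. Statements on the series, on what has been measured and on what is new or still open speak of the compounds shown alone.

In a functional assay on A549 cells (Homo sapiens) for inhibition, read by MTT assay, with a stated time of 48 h (a higher number here means a weaker inhibitor, a lower number a stronger inhibitor), compound 1 `N#Cc1ccc(-c2nc3ccccn3c2Sc2ccccc2)cc1` gives 35200 nM, while compound 2 `c1ccc(Sc2c(-c3cccs3)nc3ccccn23)cc1` gives 16900 nM, the lower of the two numbers. Compound 3 `c1ccc(Sc2c(-c3ccsc3)nc3ccccn23)cc1` carries thiophen-3-yl in place of thiophen-2-yl on an aromatic carbon. Going by the values given here, the only measured step bearing on this is modest, though beyond the scatter: a 2.1-fold lower number from compound 1 to compound 2 (0.32 log units; beyond the scatter). That step exchanged 4-cyanophenyl for thiophen-2-yl, whereas here the same atoms are merely joined differently, so no step beyond the scatter is expected in this assay. The expected step is a 1.1-fold higher number from compound 2 to compound 3 (0.03 log units; within the scatter). For compound 3 the estimated value is 18000 nM, with an expected range of 8000 nM to 38000 nM.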

Compound 3, half-maximal inhibitory concentration: 72900 nM
Estimate against measurement, compound 3: 4.1-fold (0.61 log units) below; the whole stated range lies below it.
By their numbers in this assay, from the lowest: compound 2; then compound 1; then compound 3.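

In this assay, the attachment point on the thiophene ring counts at this position: with the same atoms joined differently, the change gives a 4.3-fold higher number from compound 2 to compound 3 (0.63 log units; beyond the scatter). Thiophen-3-yl also falls behind 4-cyanophenyl, with a 2.1-fold higher number from compound 1 to compound 3 (0.32 log units; beyond the scatter), so the two thiophene isomers lie on opposite sides of 4-cyanophenyl. No evidence is available to explain this difference.

Open, going by these compounds, is whether furan-2-yl or an aminomethyl group at this position would follow thiophen-2-yl or thiophen-3-yl. Also open, on these data alone, is whether the gap between the two isomers persists when a carboxylic acid is carried on the phenylsulfanyl ring.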